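This account rests on a few compounds, and the source may have more. Where it says the series, first, only, none or still open, it means among the compounds named here.

Measured so far:

Compound 2, `C[C@H](c1ccc(-c2cc(F)ccc2-c2nc(=O)o[nH]2)cc1)N(CC1CC1)c1nc2c(C(=O)O)cccc2o1`, in an ADME assay on the whole organism (Macaca fascicularis) for pharmacokinetics, read by LC-MS, using cassette dosing, at a dose of 1 mg/kg by the oral route (on this read-out lower numbers stand for lower exposure and higher numbers for higher exposure at the dose given), gives 4410 ng.h/mL.
Compound 3, `CCCCN(c1nc2c(C(=O)O)cccc2o1)[C@H](C)c1ccc(-c2cc(F)ccc2-c2nc(=O)o[nH]2)cc1`, in this assay gives 1630 ng.h/mL.
Compound 1, `CCCCN(c1nc2c(C(=O)NC)cccc2o1)[C@H](C)c1ccc(-c2ccccc2-c2nnn[nH]2)cc1`, in this assay gives 25.7 ng.h/mL.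

Among these three, compound 2 stands highest: its nearest neighbour is compound 3, reached by a 2.7-fold lower number from compound 2 to compound 3 (0.43 log units; beyond the scatter), and compound 1 lies far below both. Among the compounds with values here, the only change measured in one place is that from compound 2 to compound 3, where propyl replaces cyclopropyl on a saturated chain carbon bound to a nitrogen on an aromatic ring; it gave a modest drop.

Compound 4, `C[C@H](c1ccc(-c2cc(Cl)ccc2-c2nc(=O)o[nH]2)cc1)N(CC1CC1)c1nc2c(C(=O)O)cccc2o1`, differs from compound 2 in a single place: chloro in place of fluoro on an aromatic carbon. Within the data shown here, no measured pair in this set swaps one halogen for another on an aromatic carbon, so the step from compound 2 to compound 3 does not bear on it directly and offers no guide for direction. With nothing to point one way or the other, the expected change in this assay from compound 2 to compound 4 is none beyond the scatter, as in a 1.1-fold lower number from compound 2 to compound 4 (0.04 log units; within the scatter). Compound 4 is therefore estimated at 4000 ng.h/mL, with a range from 1500 ng.h/mL to 10000 ng.h/mL.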

Compound 4, area under the concentration-time curve: 1300 ng.h/mL
Beside the measured number, compound 4's estimate is 3.1-fold (0.49 log units) above it; measured number below the stated range.
By their numbers in this assay, from the lowest: compound 1; then compounds 4 and 3 (each within the scatter of the next); then compound 2.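

Swapping fluoro for chloro on this aromatic carbon replaces one heavy atom with one heavy atom and leaves the hydrogen-bond donor and acceptor counts and the net charge unchanged, yet this assay shows a 3.4-fold lower number from compound 2 to compound 4 (0.53 log units; beyond the scatter). Within the data shown here, the only earlier single-place step lay on the chain bound to the nitrogen, so this is the first sign that exposure also responds to a change on this aromatic ring. Nothing shown gives a reason for the drop.

From the compounds shown here alone, how a bromo or nitrile group on this carbon would compare with fluoro and chloro remains open. So does whether the same halogen swap would lower the number to a similar extent in compound 3, which carries a different chain on the nitrogen.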